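This account rests on a few compounds, and the source may have more. Where it says the series, first, only, none or still open, it means among the compounds named here.

Three urea-linked compounds share a core built around a 2-(ethylamino)pyridin-4-yl group and were tested in an assay on isolated protein for inhibition of serine/threonine-protein kinase PLK1 (Homo sapiens), read by radiometric assay and 33P incorporation, with a stated time of 40 min, tested at 20 uM, in the presence of a further agent that is not named here; a higher number here means more inhibition at the concentration tested (going by the name of the read-out), a lower number less inhibition. Compound 1, with the structure `CCNc1cc(-c2ccc(NC(=O)Nc3ccc(C(F)(F)F)cc3)cc2C)ccn1`, gives 54.8%. Compound 2, with the structure `CCNc1cc(-c2ccc(NC(=O)Nc3cccc4ccccc34)cc2C)ccn1`, differs from compound 1 by naphthalen-1-yl in place of 4-(trifluoromethyl)phenyl on an amide-type nitrogen, and compound 2 gives 35.3%; that change produced a step of a number 19.5 percentage points lower from compound 1 to compound 2 (beyond the scatter). Compound 3, with the structure `CCNc1cc(-c2ccc(NC(=O)Nc3ccc(C(F)(F)F)cc3)cc2C(F)(F)F)ccn1`, differs from compound 1 by trifluoromethyl in place of methyl on an aromatic carbon, and compound 3 gives 82.9%, with a step of a number 28.1 percentage points higher from compound 1 to compound 3 (beyond the scatter). Compound 3 therefore stands highest of the three measured compounds.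

Compound 4, with the structure `CCNc1cc(-c2ccc(NC(=O)Nc3cccc4ccccc34)cc2C(F)(F)F)ccn1`, has not yet been measured. It differs from compound 3 by naphthalen-1-yl in place of 4-(trifluoromethyl)phenyl on an amide-type nitrogen, and the place of this change is described in the same words as the change from compound 1 to compound 2, so it is the same change made on a different core; the two cores differ by trifluoromethyl in place of methyl on an aromatic carbon.

For the measured compounds named here, the only guide to what this change does is the step from compound 1 to compound 2, so a similar downward step, a number 19.9 percentage points lower from compound 3 to compound 4 (beyond the scatter), is expected from compound 3 to compound 4, placed beside a number 19.5 percentage points lower from compound 1 to compound 2 (beyond the scatter). On that basis compound 4 is estimated at 63%, expected to fall between 45% and 78%, resting on a single earlier example of the change.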

Compound 4, a percentage reported as inhibition, at one concentration (the size of the read-out at that concentration, not a potency): 54.1%
Beside the measured number, compound 4's estimate is 8.9 percentage points above it, and the stated range covers the measured number.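

In this assay, naphthalen-1-yl in place of 4-(trifluoromethyl)phenyl on the amide-type nitrogen again brings the reading down, with a number 28.8 percentage points lower from compound 3 to compound 4 (beyond the scatter), and this step cannot be told apart from the earlier one on the other core: the same change on two cores in this assay, a number 19.5 percentage points lower (beyond the scatter) from compound 1 to compound 2 and a number 28.8 percentage points lower (beyond the scatter) from compound 3 to compound 4, 9.3 percentage points apart, within the scatter of two such steps. The reverse view of the same four compounds tells a matching story for trifluoromethyl in place of methyl on an aromatic carbon, which gives a number 18.8 percentage points higher from compound 2 to compound 4 (beyond the scatter) and agrees with its own earlier step: the same change on two cores in this assay, a number 28.1 percentage points higher (beyond the scatter) from compound 1 to compound 3 and a number 18.8 percentage points higher (beyond the scatter) from compound 2 to compound 4, 9.3 percentage points apart, within the scatter of two such steps. Together these show that, for this one set of four compounds, each change kept its direction on the second core and the two changes behaved roughly independently, but the two comparisons share the same compounds and so count as one observation, which shows neither that the changes carry over to other cores nor how potency shifts, since each reading comes from a single concentration.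

Going by these compounds, what a fluorine or a methoxy group would do on that aromatic carbon, or a pyridine ring or a cyclohexyl group on the amide-type nitrogen, remains open. On these data alone, the ethylamino group is the same in all four compounds, so the effect of a longer chain or a free amine there also remains open.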